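Pyridylmethyl Amide Variant of a Quinoline Carboxylic Acid

A few compounds are considered here, and "the series" means these few. Any claim that something is new, unique, unknown or untested is made for them only; others in the source may bear on it.

Compound 1, `COc1cc(-c2cc(C(=O)O)c3ccccc3n2)ccc1OCC(=O)Nc1ccccc1Cl`: 1.6
Compound 2, `COc1cc(-c2cc(C(=O)O)c3ccccc3n2)ccc1OCC(=O)Nc1cccc(C(F)(F)F)c1`: 1.3

Of the compounds shown here, two sharing one core have been measured in a physicochemical assay for lipophilicity, using the shake flask method, in phosphate buffer, measured as octanol-water partition, at pH 7.4; on this read-out higher numbers stand for higher lipophilicity and lower numbers for lower lipophilicity. Compound 1 gives 1.6, and compound 2 gives 1.3. Among the measured compounds shown here, the single step between them, a number 0.30 log units lower from compound 1 to compound 2 (within the scatter), is small, so on this assay compound 2 sits alongside compound 1 rather than apart from it; the two numbers cannot be ordered with confidence.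

Compound 3, `COc1cc(-c2cc(C(=O)O)c3ccccc3n2)ccc1OCC(=O)NCc1cccnc1`, has not yet been measured. It differs from compound 2 in one place: (pyridin-3-yl)methyl in place of 3-(trifluoromethyl)phenyl on an amide-type nitrogen. For the measured compounds named here, no measured step covers an exchange of this kind, since the only one known swaps one carbon-only ring for another with halogens on both sides. The expectation therefore rests on the structural change itself, in which a ring carrying three fluorines gives way to a smaller group that brings a ring nitrogen as a hydrogen-bond acceptor. On that basis compound 3 is expected to come out clearly lower than compound 2, by about a number 1.60 log units lower from compound 2 to compound 3 (beyond the scatter). The estimate for compound 3 in this assay is -0.3, within a range from -1.2 to 0.5.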

Compound 3, distribution coefficient: -0.8
Compound 3: middle estimate off by 0.50 log units, on the high side; measured number inside the range.
By their numbers in this assay, from the lowest: compound 3; then compounds 2 and 1 (each within the scatter of the next).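

In this assay the two compounds with a carbon-only ring on the amide-type nitrogen could not be told apart, but (pyridin-3-yl)methyl at that same place gives a number 2.10 log units lower from compound 2 to compound 3 (beyond the scatter) and, measured against the 2-chlorophenyl compound, a number 2.40 log units lower from compound 1 to compound 3 (beyond the scatter). The group on this nitrogen is therefore not a place where the read-out always stays put: one exchange of carbon-only rings left it within the scatter, while both exchanges for (pyridin-3-yl)methyl moved it well beyond the scatter. Nothing measured here explains why the number falls so far.

The entering group differs from those it replaces in two ways at once, with a hetero atom in its ring and an extra methyl link to the nitrogen, and the loss of the chlorine or the trifluoromethyl comes on top, so these compounds cannot say which of these changes carries the step. Going by these compounds, a plain benzyl group on the same nitrogen, or a pyridin-3-yl ring attached without the link, would pull these changes apart, and how far the number moves with either remains open.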